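Fluorine on the phenyl of a pyrazolopyrimidine Ret inhibitor

The source may hold more compounds than are shown below. What is called first, only, known or untested is meant among the compounds shown, and "the series" means these compounds.

Measured so far:
compound 1, `CC(C)n1nc(-c2cc(-c3ccccc3)on2)c2c(N)ncnc21`: > 10000 nM
compound 2, `CC(C)n1nc(/C=N/OCc2ccccc2)c2c(N)ncnc21`: 9270 nM

The two compounds were tested in an assay on TT cells for inhibition of proto-oncogene tyrosine-protein kinase receptor Ret variant C634W (Homo sapiens), read by MTT assay, with a stated time of 10 days; on this read-out higher numbers stand for weaker inhibition of growth and lower numbers for stronger inhibition of growth. For compound 1 the entry > 10000 nM is a limit of the assay and not a number; it sits at the limit of > 10000 nM in this assay, at which 1 of the 2 values shown sits. Compound 2 gives 9270 nM in this assay, a weak effect as well. No step between two measured compounds is shown here, so the pair says only that neither compound reaches a measurable strong inhibition of growth.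

The account turns from compound 1 to compound 3, `CC(C)n1nc(-c2cc(-c3ccc(F)cc3)on2)c2c(N)ncnc21`, which has not yet been measured. The change is small: fluoro in place of hydrogen on an aromatic carbon. For the measured compounds named here, nothing among the measured compounds tells how such a change acts, and for the step from compound 1 to compound 3 an expectation of no change beyond the scatter is the most that can be said, with the estimated step that the limit leaves unreadable from compound 1 to compound 3 as the step. Compound 3 is therefore expected to give about 15000 nM in this assay, within a range from 5000 nM to 50000 nM, and most likely the assay will again report only a limit.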

Compound 3, concentration for 50% growth inhibition: > 10000 nM
Compound 3 ended at the assay's limit; the forecaster's own chance of this, stated with the estimate: 70%; the middle value is on the limit's open side.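

In this assay compound 3 gives > 10000 nM, which is a limit of the assay and not a number. Compound 1 also stands at a limit, so no step can be read between compound 1 and compound 3: the limit of > 10000 nM in this assay, at which 2 of the 3 values shown sit.

The compounds shown leave open whether the change from phenyl to 4-fluorophenyl alters growth inhibition at all.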